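Working notes on the series, compounds 1 to 4

This account rests on a few compounds, and the source may have more. Where it says the series, first, only, none or still open, it means among the compounds named here.

Three measured compounds share one core, all read in a functional assay on the whole organism with Mus musculus as the target; on this read-out higher numbers stand for higher potency (the scale is a negative logarithm) and lower numbers for lower potency. Compound 1 `CN1CCC(OC(=O)c2ccccc2Cc2ccccc2)CC1` gives 1.28, compound 2 `CN1CCC(OC(=O)c2ccccc2F)CC1` gives 1.41, and compound 3 `COc1ccccc1C(=O)OC1CCN(C)CC1` gives 1.43. Compound 3 carries the highest of the three numbers, yet a number 0.15 log units higher from compound 1 to compound 3 (within the scatter) and a number 0.02 log units higher from compound 2 to compound 3 (within the scatter) both fall within the scatter, so no order among the three is claimed. The next step leads to compound 4 `CN1CCC(OC(=O)c2ccccc2Br)CC1`, with bromo in place of methoxy on an aromatic carbon. Within the data shown here, the steps that bear on this exchange at the same position, together with a number 0.13 log units higher from compound 1 to compound 2 (within the scatter), all stayed within the scatter. For compound 4 no shift beyond the scatter is therefore expected in this assay, namely a number 0.01 log units lower from compound 3 to compound 4 (within the scatter). Compound 4 is estimated at 1.42, with a range from 1.1 to 1.75.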

Compound 4, logarithm of the reciprocal of the active concentration, log(1/C): 1.21
For compound 4 the middle estimate is 0.21 log units above the measured one; the measured number falls inside the stated range.
By their numbers in this assay, from the lowest: compounds 4, 1, 2 and 3 (each within the scatter of the next).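

Bromo on this aromatic carbon, ortho to a large group, also stays within the scatter in this assay against methoxy (a number 0.22 log units lower from compound 3 to compound 4 (within the scatter)), fluoro (a number 0.20 log units lower from compound 2 to compound 4 (within the scatter)) and benzyl (a number 0.07 log units lower from compound 1 to compound 4 (within the scatter)). All steps among these four groups at this position therefore stay within the scatter, now including one with a bromine atom. No supporting data accompany these results.

Going by these compounds, whether an amine, a carboxylic acid or a longer chain on this carbon would give a step beyond the scatter remains open.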